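Amide aryl variation on the shared core

The compounds below may be only part of what the source reports. "The series", "measured", "known", "first", "only" and "open" are said of these compounds alone.

Measured so far in a functional assay on HeLa cells (Homo sapiens) for antiproliferative activity, read by CCK-8 assay, with a stated time of 72 h; a lower number here means a stronger inhibitor, a higher number a weaker inhibitor:
compound 1 `O=C(Nc1cccc(-c2oc3cc(-c4ccc(F)cc4)ccc3c(=O)c2O)c1)c1ccc(F)cc1F`: 10700 nM
compound 2 `Cc1cc(C(=O)Nc2cccc(-c3oc4cc(-c5ccc(F)cc5)ccc4c(=O)c3O)c2)ccc1F`: 18900 nM

Compound 1 stands at the lower of the two numbers in this assay; its nearest neighbour is compound 2, a 1.8-fold higher number from compound 1 to compound 2 (0.25 log units; within the scatter). Compound 3 `CCCc1ccc(C(=O)Nc2cccc(-c3oc4cc(-c5ccc(F)cc5)ccc4c(=O)c3O)c2)cc1` differs from compound 1 at the carbonyl carbon: 4-propylphenyl in place of 2,4-difluorophenyl on a carbonyl carbon. Within the data shown here, the only step that bears on this exchange is the one from compound 1 to compound 2, which stayed within the scatter, so no step beyond the scatter is expected in this assay. Compound 3 is therefore estimated at 12000 nM, ranging from 5000 nM to 30000 nM, which means an expected 1.1-fold higher number from compound 1 to compound 3 (0.05 log units; within the scatter).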

Compound 3, half-maximal inhibitory concentration: 8790 nM
For compound 3 the middle estimate is 1.4-fold (0.14 log units) above the measured one; measured number inside the range.
By their numbers in this assay, from the lowest: compounds 3, 1 and 2 (each within the scatter of the next, the first and the last beyond it).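

In this assay the aryl group on the amide carbonyl accepts 4-propylphenyl, which carries no fluorine, with a 1.2-fold lower number from compound 1 to compound 3 (0.09 log units; within the scatter) showing no change from 2,4-difluorophenyl. Among these compounds, the same group gives the only step at this position beyond the scatter, a 2.2-fold lower number from compound 2 to compound 3 (0.33 log units; beyond the scatter), and that step is modest. Nothing measured here accounts for either step. Still open, on these data alone, is whether an amine or a carboxylic acid on this aryl ring, or a chain longer than propyl, would shift the number further.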